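Swapping one carboxyphenyl group for another

This account rests on a few compounds, and the source may have more. Where it says the series, first, only, none or still open, it means among the compounds named here.

Compound 1 `O=C1c2ccc(OCc3cccc(-c4ccc(Cl)cc4F)c3)cc2CN1C1CCCC1` gives "not determined" (no result reported)
Compound 2 `O=C(O)c1cc(-c2cccc(COc3ccc4c(c3)CN(C3CCCC3)C4=O)c2)ccc1O` gives 9%

Among the compounds with values here, in an ADME assay on microsomes from liver (Rattus norvegicus) for metabolic stability, read by LC-MS, with a stated time of 1 h, at 37 degrees C, tested at 4 uM (a lower number here means that less of the compound is left, a higher number that more of the compound is left), compound 2 gives 9%, the only number available, so it cannot yet be ranked against anything. Compound 3 `O=C(O)c1ccc(Cl)c(-c2cccc(COc3ccc4c(c3)CN(C3CCCC3)C4=O)c2)c1` carries 5-carboxy-2-chlorophenyl in place of 3-carboxy-4-hydroxyphenyl on an aromatic carbon. Within the data shown here, no measured pair shows what such a change does in this assay. Compound 2 at 9% leaves little room to fall, so a rise is the likelier direction. The expected change is a number 16 percentage points higher from compound 2 to compound 3 (beyond the scatter), and it is uncertain. For compound 3 the estimated value is 25%, with a range of 8% to 60%.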

Compound 3, percent of the compound remaining: 15%
The estimate for compound 3 lay 10 percentage points above the measured number; the measured number falls inside the stated range.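

In this assay, within the data shown here, putting 5-carboxy-2-chlorophenyl in place of 3-carboxy-4-hydroxyphenyl on this aromatic carbon gives a number 6 percentage points higher from compound 2 to compound 3 (within the scatter) and provides the first measured pair at this position. This exchange, which retains the carboxylic acid, therefore does not separate the two compounds in this test. No supporting data bear on this result.

Going by these compounds, whether an amine or a nitrile in place of the carboxylic acid on this ring would give a step beyond the scatter in this assay remains open. On these data alone, the separate contributions of the chlorine and the hydroxyl also remain open.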